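Working notes on a liver microsome stability series

The source may hold more compounds than are shown below. What is called first, only, known or untested is meant among the compounds shown, and "the series" means these compounds.

Of the compounds shown here, three have been measured in an ADME assay on microsomes from liver (Mus musculus) for metabolic stability; on this read-out higher numbers stand for a longer-lived compound and lower numbers for a shorter-lived compound.
Compound 1, `CC(C)C(c1ccc(-c2ccc3cccc(F)c3c2)[nH]c1=O)N1CCCCC1=O`, gives 0.0967 h.
Compound 2, `CC(C)C(Nc1nccs1)c1ccc(-c2ccc3cccc(F)c3c2)[nH]c1=O`, gives 0.0733 h.
Compound 3, `CC(C)C(c1ccc(-c2ccc3cccc(F)c3c2)[nH]c1=O)N1CCNC1=O`, gives 0.682 h.

Compound 3 stands highest of the three numbers. The steps of a 7.1-fold higher number from compound 1 to compound 3 (0.85 log units; beyond the scatter) and a 9.3-fold higher number from compound 2 to compound 3 (0.97 log units; beyond the scatter) both lie beyond the scatter, whereas a 1.3-fold lower number from compound 1 to compound 2 (0.12 log units; within the scatter) does not, so compounds 1 and 2 cannot be ordered against each other.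

Compound 4, `Cc1nc(C(c2ccc(-c3ccc4cccc(F)c4c3)[nH]c2=O)C(C)C)[nH]c1C`, differs from compound 3 in one place: 4,5-dimethyl-1H-imidazol-2-yl in place of 2-oxoimidazolidin-1-yl on a saturated chain carbon bound to an aromatic carbon and a saturated chain carbon. For the measured compounds named here, the steps that bear on this change are a 7.1-fold higher number from compound 1 to compound 3 (0.85 log units; beyond the scatter) and a 9.3-fold higher number from compound 2 to compound 3 (0.97 log units; beyond the scatter): in both, the 2-oxoimidazolidin-1-yl group carried the higher number, and the lowest number of the set belongs to compound 2, whose group at the same chain carbon is, like the entering 4,5-dimethyl-1H-imidazol-2-yl, a five-membered aromatic ring with two hetero atoms and one hydrogen-bond donor. On that basis a downward step is expected for compound 4, modest in size and roughly the reverse of a 9.3-fold higher number from compound 2 to compound 3 (0.97 log units; beyond the scatter), though with wide uncertainty since no aromatic group of this exact kind has been measured.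

Compound 4 is therefore estimated at 0.2 h, within a range of 0.07 h to 0.6 h, corresponding to an expected step of a 3.4-fold lower number from compound 3 to compound 4 (0.53 log units; beyond the scatter).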

Compound 4, half-life: 0.0817 h
Compound 4: the middle estimate sits 2.4-fold (0.39 log units) above what was measured; the range from low to high includes it.
By their numbers in this assay, from the lowest: compounds 2, 4 and 1 (each within the scatter of the next); then compound 3.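

In this assay, the step of an 8.3-fold lower number from compound 3 to compound 4 (0.92 log units; beyond the scatter) shows that a five-membered ring with 2 hetero atoms at this saturated chain carbon does not by itself keep the higher number: 4,5-dimethyl-1H-imidazol-2-yl is aromatic where 2-oxoimidazolidin-1-yl is not, and the two groups have the same hydrogen-bond donor and acceptor counts. The steps of a 1.1-fold higher number from compound 2 to compound 4 (0.05 log units; within the scatter) and a 1.2-fold lower number from compound 1 to compound 4 (0.07 log units; within the scatter) place the new group with (1,3-thiazol-2-yl)amino and 2-oxopiperidin-1-yl, so three groups of different ring type now stand together, and among these four compounds only compound 3 lies beyond the scatter from all the others. Nothing available explains this change at the position.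

From the compounds shown here alone, what an unsubstituted 1H-imidazol-2-yl would give at the same chain carbon stays open, so the part played by the two methyl groups cannot be separated from that of the aromatic ring. Also open, going by these compounds, is whether 2-oxopyrrolidin-1-yl, a five-membered lactam without the second ring nitrogen, would follow compound 3 or compound 1.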